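Cytotoxicity notes on the biaryl amide series, bromo replacement

A few compounds are considered here, and "the series" means these few. Any claim that something is new, unique, unknown or untested is made for them only; others in the source may bear on it.

Measured so far:
compound 1 `CCOC(=O)CCCCCOc1cccc(CN(C(=O)c2ccc(-c3cnc(OC)nc3OC)cc2)C(C)C)c1` — > 26000 nM
compound 2 `CCOC(=O)CCCCCOc1cccc(CN(C(=O)c2ccc(-c3ccc4[nH]ccc4c3)cc2)C(C)C)c1` — > 26000 nM

In an ADME assay on HepG2 cells (Homo sapiens) for cytotoxicity, read by CellTiter-Glo and resazurin assay, with a stated time of 72 h (a higher number here means that more compound is needed for the effect, a lower number that less compound is needed), compound 1 reaches only the limit of the assay, > 26000 nM, not a number. Compound 2 likewise gives only the limit > 26000 nM in this assay. The step that the two limits leave unreadable from compound 1 to compound 2 is therefore not readable from the two limits. Among the compounds with values here, compound 2 thus stands at a limit, and the one further value shown is a limit as well: both sit at the limit of > 26000 nM in this assay, at which 2 of the 2 values shown sit.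

Compound 3 `CCOC(=O)CCCCCOc1cccc(CN(C(=O)c2ccc(Br)cc2)C(C)C)c1` has not yet been measured in this assay. It differs from compound 2 by bromo in place of 1H-indol-5-yl on an aromatic carbon. Within the data shown here, the only measured step, from compound 1 to compound 2, is unreadable, so no step of known size bears on this change; what is known is that both neighbours of the series sit at the limit. The expectation for compound 3 is therefore no step beyond the scatter, a step that the limit leaves unreadable from compound 2 to compound 3, with a fair chance that again only a limit is returned. The estimate for compound 3 in this assay is 30000 nM, within 12000 nM to 90000 nM.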

Compound 3, half-maximal effective concentration: > 26000 nM
Compound 3 ended at the assay's limit (the forecaster's own chance of this, stated with the estimate: 70%); the middle value does not contradict the limit.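

Compound 1, compound 2 and compound 3 all end at a limit, not a number, in this assay, so no step among them can be read: the limit of > 26000 nM in this assay, at which 3 of the 3 values shown sit.

The compounds shown leave open where the half-maximal effective concentration of any of them lies in this assay, and whether bromo, 1H-indol-5-yl and 2,4-dimethoxypyrimidin-5-yl differ there at all.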